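A Hydroxyphenyl Group in Place of Hydrogen on Nitrogen

This account rests on a few compounds, and the source may have more. Where it says the series, first, only, none or still open, it means among the compounds named here.

Measured so far in a functional assay on the whole organism (strain Swiss) for inhibition, with Mus musculus as the target, with a stated time of 30 min, at a dose of 10 mg/kg by the intraperitoneal route; a lower number here means a weaker effect, a higher number a stronger effect of the compound at the dose given:
compound 1 `Nc1nc(Cl)nc(Nc2ccc(N3CCOCC3=O)cc2)n1` gives 74%
compound 2 `O=C1COCCN1c1ccc(Nc2nc(Cl)nc(Nc3ccc(Cl)cc3)n2)cc1` gives 90.2%

Compound 1 stands lowest of the two numbers in this assay; its nearest neighbour is compound 2, reached by putting 4-chlorophenyl in place of hydrogen on a nitrogen on an aromatic ring, a step of a number 16.2 percentage points higher from compound 1 to compound 2 (beyond the scatter), which is modest but beyond the scatter.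

Compound 3 `O=C1COCCN1c1ccc(Nc2nc(Cl)nc(Nc3ccc(O)cc3)n2)cc1` is not yet measured. It differs from compound 1 by 4-hydroxyphenyl in place of hydrogen on a nitrogen on an aromatic ring. For the measured compounds named here, the same position and the same kind of addition, a six-membered aromatic ring on that nitrogen, gave the one measured step, so compound 3 is expected to move in the same direction, upward, by roughly a number 11 percentage points higher from compound 1 to compound 3 (beyond the scatter), because the step of a number 16.2 percentage points higher from compound 1 to compound 2 (beyond the scatter) points that way. For compound 3 the estimated inhibition in this assay is 85%, within 70% to 96%.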

Compound 3, a percentage reported as inhibition, in the whole organism at one dose (the size of the read-out at that dose, not a potency): 68%
For compound 3 the middle estimate is 17 percentage points above the measured one, and the stated range ends above it.
By their numbers in this assay, from the lowest: compounds 3 and 1 (each within the scatter of the next); then compound 2.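

In (this assay), a six-membered aromatic ring on this nitrogen does not by itself ensure a stronger effect: with 4-hydroxyphenyl in place of hydrogen, the result is (a number 6 percentage points lower from compound 1 to compound 3 (within the scatter)). The group carried by that ring matters among these compounds, as hydroxy in place of chloro on an aromatic carbon gives (a number 22.2 percentage points lower from compound 2 to compound 3 (beyond the scatter)). Nothing given here explains why these two groups differ.

Still open, going by these compounds, is how a plain phenyl group, with neither chloro nor hydroxy, would compare, which would help separate the contribution of the ring from that of the group it carries. Also open, on these data alone, is how other groups in place of chloro on that aromatic carbon, such as methoxy, an amine or a carboxylic acid, would compare with chloro and hydroxy.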